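From ethynyl to 2-phenylethynyl: one expected step

This account rests on a few compounds, and the source may have more. Where it says the series, first, only, none or still open, it means among the compounds named here.

compound 1 `C#Cc1cccc(N/N=N/c2ccc(C(=N)N)cc2)c1` gives 16800 nM
compound 2 `C#Cc1ccc(N/N=N/c2ccc(C(=N)N)cc2)cc1` gives 11800 nM

Among the compounds with values here, both values come from a functional assay on OVCAR-3 cells (Homo sapiens) for antiproliferative activity, read by WST assay, with a stated time of 72 h (on this read-out higher numbers stand for weaker inhibition of growth and lower numbers for stronger inhibition of growth), and are the only measurements so far. Compound 1 and compound 2 lie within the usual scatter of each other, so the numbers do not separate them. Within the data shown here, no measured pair of compounds differing in one place is available as a guide.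

Compound 3 `N=C(N)c1ccc(/N=N/Nc2cccc(C#Cc3ccccc3)c2)cc1` has not yet been measured. It keeps the core of compound 1 but has phenyl in place of hydrogen on a triple-bonded carbon, which turns ethynyl into 2-phenylethynyl phenyl in place of hydrogen on a triple-bonded carbon as the single difference. Among the measured compounds shown here, with no measured precedent for this change, the size of the step is uncertain. A modest move toward a lower number is expected in this assay and the result may still stay within the scatter. The expected size is a 2.8-fold lower number from compound 1 to compound 3 (0.45 log units; beyond the scatter) with wide uncertainty around it. Compound 3 is expected at 6000 nM (estimated range 1500 nM to 20000 nM).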

Compound 3, concentration for 50% growth inhibition: 6500 nM
Compound 3: middle estimate off by 1.1-fold (0.03 log units), on the low side; the measured number falls inside the stated range.
By their numbers in this assay, from the lowest: compounds 3, 2 and 1 (each within the scatter of the next, the first and the last beyond it).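

In this assay, within the data shown here, the replacement of hydrogen by phenyl on a triple-bonded carbon gives a 2.6-fold lower number from compound 1 to compound 3 (0.41 log units; beyond the scatter) as the first step in this small series that can be read, and it is a modest one. Among these compounds, it shows that this carbon, which carries only hydrogen in compound 1, can take a six-membered aromatic ring of carbon only while the number falls rather than rises, something compound 1 and compound 2 alone could not show, as they offered no step of this kind. Nothing measured here bears on why the number moves, so the step stands as an observation only.

The compounds shown leave open whether a small group such as methyl, a saturated ring such as cyclohexyl, or a chain ending in an amine on the same triple-bonded carbon would move the number as phenyl does, and so whether the aromatic ring matters at all. They also leave open whether the same change, ethynyl to 2-phenylethynyl, made on compound 2 would give a step of similar size.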